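A Piperidinylcarbonyl Replacement on the Shared Core

The source may hold more compounds than are shown below. What is called first, only, known or untested is meant among the compounds shown, and "the series" means these compounds.

Compound 1 `COc1ccc(-c2nc(/N=C(\N)NC3CCCCC3)sc2-c2ccc(OC)cc2)cc1` was tested in a functional assay with Oryctolagus cuniculus as the target; a higher number here means a weaker inhibitor, a lower number a stronger inhibitor. In this assay compound 1 reaches only the limit of the assay, > 1000 nM, so no number is known for it. Compound 2 `COc1ccc(-c2nc(/N=C(\N)n3ccnc3)sc2-c2ccc(OC)cc2)cc1` carries 1H-imidazol-1-yl in place of cyclohexylamino on a carbon with a double bond to nitrogen; in this assay compound 2 likewise stands at a limit, > 100 nM. Compound 3 `COc1ccc(-c2nc(C(N)=O)sc2-c2ccc(OC)cc2)cc1` has a group of 3 heavy atoms in place of a group of 10 heavy atoms on an aromatic carbon, and in this assay compound 3 also stops at a limit, > 1000 nM. The steps a step that the two limits leave unreadable from compound 1 to compound 2, a step that the two limits leave unreadable from compound 1 to compound 3 and a step that the two limits leave unreadable from compound 2 to compound 3 therefore carry no readable size; the limit of > 1000 nM in this assay, at which 2 of the 3 values shown sit, and the limit of > 100 nM in this assay, at which 1 of the 3 values shown sits, are all the evidence there is.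

Compound 4 `COc1ccc(-c2nc(C(=O)N3CCCCC3)sc2-c2ccc(OC)cc2)cc1` differs from compound 1 by a group of 8 heavy atoms (6 carbon, 1 nitrogen, 1 oxygen; one six-membered non-aromatic ring with 1 hetero atom) in place of a group of 10 heavy atoms (7 carbon, 3 nitrogen; one six-membered non-aromatic ring of carbon only), on an aromatic carbon. The nearest point of comparison is compound 3, whose carbonyl-bearing group also took the place of the group of 10 heavy atoms, and that compound stayed at a limit. Going by the values given here, since no measured step is readable, no step of any particular size or direction can be expected in this assay. Compound 4 is expected to give 3000 nM, between 800 nM and 20000 nM, most likely reported again only as a limit. The estimated step that the limit leaves unreadable from compound 1 to compound 4 thus means no change beyond what the limits already hide.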

Compound 4, half-maximal inhibitory concentration: > 1000 nM
Compound 4: a limit, no number; the forecaster's own chance of this, stated with the estimate: 80%; the middle value does not contradict the limit.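

In this assay compound 4 gives > 1000 nM, which is a limit and not a number, so its steps from compound 1, compound 2 and compound 3 cannot be read. The compounds shown leave open whether any of these groups at this place on the shared core gives a numerical value at all, and how the groups would rank: the limit of > 1000 nM in this assay, at which 3 of the 4 values shown sit.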